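Chloro added to the phenoxy ring of compound 2

This account rests on a few compounds, and the source may have more. Where it says the series, first, only, none or still open, it means among the compounds named here.

Measured compounds in a functional assay on HepG2 cells (Homo sapiens) for antiproliferative activity, tested at 1 uM; a lower number here means less inhibition, a higher number more inhibition at the concentration tested (going by the name of the read-out):
compound 1, `COc1ccc(CO/N=C/c2c(C)nn(C)c2Oc2ccc(Cl)cc2)cc1`, 13.9%
compound 2, `Cc1nn(C)c(Oc2ccccc2)c1/C=N/OCc1ccc(C(F)(F)F)cc1`, 5.8%

The two measured compounds share a core and differ in two places: the phenoxy ring (with or without chloro) and the benzyloxy group (methoxy or trifluoromethyl). Going by the values given here, compound 2 gives 5.8%, compound 1 gives 13.9%; the gap between them lies within the scatter, so the two cannot be separated on these numbers, and no single step between them is counted.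

Compound 3, `Cc1nn(C)c(Oc2ccc(Cl)cc2)c1/C=N/OCc1ccc(C(F)(F)F)cc1`, has not yet been measured. It differs from compound 2 in one place:

chloro in place of hydrogen on an aromatic carbon

Among the compounds with values here, the only clue is compound 1, which carries the same chloro and gives 13.9%, a number not distinguishable from compound 2. For compound 3 the expected step of a number 5.2 percentage points higher from compound 2 to compound 3 (within the scatter) is therefore small and upward at most, with no change beyond the scatter as the likeliest case. Compound 3 is estimated at 11%, within the range 2% to 25%.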

Compound 3, a percentage reported as inhibition, at one concentration (the size of the read-out at that concentration, not a potency): 20.6%
The estimate for compound 3 lay 9.6 percentage points below the measured number; low and high end bracket the measured number.
By their numbers in this assay, from the lowest: compounds 2, 1 and 3 (each within the scatter of the next, the first and the last beyond it).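

In this assay, going by these compounds alone, with the trifluoromethyl benzyloxy group held constant, phenoxy to 4-chlorophenoxy gives a number 14.8 percentage points higher from compound 2 to compound 3 (beyond the scatter) and is the first change in one place that can be read, which the two earlier compounds could not provide as they differ in two places. Within the data shown here, with the 4-chlorophenoxy group held constant, trifluoromethyl in place of methoxy on an aromatic carbon gives a number 6.7 percentage points higher from compound 1 to compound 3 (within the scatter) and so cannot be told apart from no change, which leaves chloro as the only single change so far with a step beyond the scatter. No measurement on hand bears on the reason for the chloro step.

The chloro step is shown with the trifluoromethyl benzyloxy group only, so its size with methoxy in that place stays open. As far as these compounds go, whether the step belongs to chloro itself or would also appear with another group on the same aromatic carbon, such as fluoro, methyl, an amine or a carboxylic acid, is also open.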